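Removing the Methoxyphenyl Arm from a Thiazole Hydroxamate

The source may hold more compounds than are shown below. What is called first, only, known or untested is meant among the compounds shown, and "the series" means these compounds.

Compound 3 `COc1ccc(-c2cnc(-c3nc(C(=O)N[C@@H](C)c4ccc(C(=O)NO)cc4)c(C4CC4)s3)s2)cc1` gives 2.38 nM in an assay on cells for inhibition of protein deacetylase HDAC6 (Homo sapiens), read by fluorescence, with a stated time of 24 h (on this read-out higher numbers stand for weaker inhibition and lower numbers for stronger inhibition), the lowest of the three numbers at hand. Compound 1 `CC(C)[C@H](NC(=O)c1nc(-c2nccs2)sc1C1CC1)c1ccc(C(=O)NO)cc1` gives 14.2 nM in this assay and compound 2 `Cc1csc(-c2nc(C(=O)N[C@@H](C)c3ccc(C(=O)NO)cc3)c(C3CC3)s2)n1` gives 19.1 nM, both well beyond the scatter from compound 3. Compound 4 `C[C@H](NC(=O)c1nc(-c2nccs2)sc1C1CC1)c1ccc(C(=O)NO)cc1` has not been measured; relative to compound 3 the change is hydrogen in place of 4-methoxyphenyl on an aromatic carbon. Compound 4 carries the same unsubstituted thiazole arm as compound 1 and a single methyl as in compound 2, so a step back toward those numbers is expected, from compound 3 to compound 4 estimated as a 6.3-fold higher number from compound 3 to compound 4 (0.80 log units; beyond the scatter), a loss clearly beyond the scatter. Compound 4 is therefore estimated at 15 nM in this assay, within 7 nM to 35 nM.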

Compound 4, half-maximal inhibitory concentration: 14 nM
Beside the measured number, compound 4's estimate is 1.1-fold (0.03 log units) above it; the range from low to high includes it.
By their numbers in this assay, from the lowest: compound 3; then compounds 4, 1 and 2 (each within the scatter of the next).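

With the arm gone, a 5.9-fold higher number from compound 3 to compound 4 (0.77 log units; beyond the scatter) in this assay ties the low number of compound 3 to the 4-methoxyphenyl on the aromatic carbon next to the ring sulfur. At that carbon, hydrogen and methyl cannot be told apart, as a 1.4-fold lower number from compound 2 to compound 4 (0.13 log units; within the scatter) shows, and the same holds for methyl and isopropyl on the saturated chain carbon, as a 1.0-fold lower number from compound 1 to compound 4 (0.01 log units; within the scatter) shows. Nothing on hand explains the step from the arm to hydrogen. The compounds shown leave open whether a plain phenyl or a lone methoxy on that carbon would hold the low number, and how an amine in place of the methoxy on the arm would read.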